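This account rests on a few compounds, and the source may have more. Where it says the series, first, only, none or still open, it means among the compounds named here.

Measured so far:
compound 1 `Oc1ccc(-c2cc(-c3ccccc3)cc(-c3ccccc3)n2)cc1`, 43.6%
compound 2 `Oc1ccc(-c2cc(-c3ccccc3)cc(-c3ccsc3)n2)cc1`, "not determined" (no result reported)

In an assay on isolated protein for inhibition of DNA topoisomerase 1 (Homo sapiens), with a stated time of 30 min, tested at 20 uM (on this read-out lower numbers stand for a weaker effect and higher numbers for a stronger effect at the one concentration tested), compound 1 gives 43.6%. For compound 2 no number exists in this assay, so compound 2 stands nowhere on the scale; the only fixed point in the series is compound 1. Compound 3 `Oc1ccc(-c2cc(-c3ccccc3)cc(-c3cccnc3)n2)cc1` differs from compound 2 by pyridin-3-yl in place of thiophen-3-yl on an aromatic carbon. For the measured compounds named here, no measured step between two compounds exists, so the size of the step from compound 2 to compound 3 in this assay cannot be read from data; the expectation is a shift within the scatter, in either direction, near the level of compound 1. Compound 3 is expected to give about 38% in this assay, within 10% to 65%.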

Compound 3, a percentage reported as inhibition, at one concentration (the size of the read-out at that concentration, not a potency): 0.9%
Estimate against measurement, compound 3: 37.1 percentage points above; the whole stated range lies above it.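

In this assay, pyridin-3-yl in place of phenyl on this aromatic carbon, next to the ring nitrogen, gives a number 42.7 percentage points lower from compound 1 to compound 3 (beyond the scatter). For the compounds shown here, this is the first readable step, and it shows that the position does not treat these six-membered aromatic rings alike: a single ring nitrogen in the substituent separates a clear read-out from almost none. Steps involving compound 2 cannot be read, so thiophen-3-yl remains unplaced.

From the compounds shown here alone, whether a saturated ring such as piperidine, or an amine on the phenyl group, would hold or lose the effect at this position remains open. No measurement at hand accounts for the drop.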